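A few compounds are considered here, and "the series" means these few. Any claim that something is new, unique, unknown or untested is made for them only; others in the source may bear on it.

Measured so far:
- compound 1, `CC(C)=CCOc1c(C)c(C)c2c(c1C)CCC(C)(COc1ccc(/C=C3\SC(=O)NC3=O)cc1F)O2`: 95%
- compound 2, `CCOc1cc(/C=C2\SC(=O)NC2=O)ccc1OCC1(C)CCc2c(C)c(OCC=C(C)C)c(C)c(C)c2O1`: 107%
- compound 3, `CC(C)=CCOc1c(C)c(C)c2c(c1C)CCC(C)(COc1ccc(/C=C3\SC(=O)NC3=O)cc1)O2`: 76%

In a functional assay on MCF7 cells (Homo sapiens), tested at 2.5 uM (a higher number here means a weaker effect of the compound at the concentration tested, a lower number a stronger effect), compound 3 stands lowest of the three numbers. Its nearest neighbour is compound 1, the gap being a number 19 percentage points lower from compound 1 to compound 3 (beyond the scatter); the furthest is compound 2, the gap being a number 31 percentage points lower from compound 2 to compound 3 (beyond the scatter). Both steps remove a group from the same aromatic carbon and both lower the number beyond the scatter.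

Compound 4, `CC(C)=CCOc1c(C)c(C)c2c(c1C)CCC(C)(COc1ccc(/C=C3\SC(=O)NC3=O)cc1Br)O2`, is not yet measured. It differs from compound 3 by bromo in place of hydrogen on an aromatic carbon. The two steps that bear on it run the other way: reading them backward, putting fluoro or ethoxy onto that carbon raises the number in this assay, modestly in the first case and by a large amount in the second. For the measured compounds named here, a group entering at that carbon is therefore expected to raise the number again, by a step beyond the scatter, of modest to large size; the data hold no bromo compound, so the exact size is open.

Compound 4 is expected to give 95% in this assay, with a range from 78% to 112%. The expected step is a number 19 percentage points higher from compound 3 to compound 4 (beyond the scatter).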

Compound 4, a percentage reported as activity, at one concentration (the size of the read-out at that concentration, not a potency): 96%
Beside the measured number, compound 4's estimate is 1 percentage points below it, within the range that was stated.
By their numbers in this assay, from the lowest: compound 3; then compounds 1 and 4 (each within the scatter of the next); then compound 2.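

In this assay, bromo at this aromatic carbon, ortho to a large group, is a third group after fluoro and ethoxy to give a higher number than hydrogen, with a number 20 percentage points higher from compound 3 to compound 4 (beyond the scatter). Bromo and fluoro cannot be told apart at this carbon, with a number 1 percentage points higher from compound 1 to compound 4 (within the scatter), while ethoxy remains separate from bromo, with a number 11 percentage points lower from compound 2 to compound 4 (beyond the scatter). Among these four compounds, hydrogen therefore gives the lowest number, and no compound goes against this.

No measurement here accounts for these differences between the groups. On these data alone, it remains open whether an amine, a hydroxyl or a carboxylic acid at this carbon would also raise the number or leave it at the level seen with hydrogen. As far as these compounds go, whether a longer chain than ethoxy would move the number further is also open.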